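Swapping the Group on the Amide Nitrogen of Compound 2

The source may hold more compounds than are shown below. What is called first, only, known or untested is meant among the compounds shown, and "the series" means these compounds.

Measured in a functional assay on BXPC-3 cells (Homo sapiens) for antiproliferative activity, read by MTT assay, with a stated time of 24 h; on this read-out lower numbers stand for stronger inhibition and higher numbers for weaker inhibition:
- compound 1 `CCn1c(C(=O)N[C@@H](CC(=O)OC)C(=O)OC)ccc1C(CC)(CC)c1ccc(OCS(=O)(=O)c2ccccc2)c(C)c1` gives > 50000 nM
- compound 2 `CCn1c(C(=O)N[C@@H](CO)CCCO)ccc1C(CC)(CC)c1ccc(OCS(=O)(=O)c2ccccc2)c(C)c1` gives 16400 nM

Compound 1 reads > 50000 nM, which is a limit of the assay and not a number. For the measured compounds named here, compound 2, at 16400 nM, therefore holds the only true number so far.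

Compound 3 `CCn1c(C(=O)N[C@H](C(=O)O)C(C)C)ccc1C(CC)(CC)c1ccc(OCS(=O)(=O)c2ccccc2)c(C)c1` keeps the shared core and changes only the group on the amide-type nitrogen, where 1-carboxy-2-methylpropyl enters: a group of 7 heavy atoms (5 carbon, 2 oxygen; no ring) in place of a group of 7 heavy atoms (5 carbon, 2 oxygen; no ring), on an amide-type nitrogen.

Going by the values given here, the only measured step is an at least 3.0-fold lower number from compound 1 to compound 2 (0.48 log units; beyond the scatter). It also concerns the group on this nitrogen, so it shows that a change there can shift the number. However, it involves a different exchange, and no measured compound carries the entering group. It therefore offers only loose guidance on size and none on direction. With compound 2 at 16400 nM as the anchor, little change is expected, with a slight lean toward weaker inhibition. The expected change is a 1.5-fold higher number from compound 2 to compound 3 (0.18 log units; within the scatter). The estimated value for compound 3 is 25000 nM, within an expected range of 8000 nM to 70000 nM.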

Compound 3, half-maximal inhibitory concentration: 16200 nM
Beside the measured number, compound 3's estimate is 1.5-fold (0.19 log units) above it; measured number inside the range.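

In this assay, the new result gives a 1.0-fold lower number from compound 2 to compound 3 (0.01 log units; within the scatter), which lies within the usual scatter. Two different groups on the amide-type nitrogen, 1-carboxy-2-methylpropyl and the group it replaces, therefore cannot be told apart here, even though they have the same heavy-atom count and differ in their hydrogen-bond donor and acceptor counts. Going by these compounds, the other new step is an at least 3.0-fold lower number from compound 1 to compound 3 (0.48 log units; beyond the scatter), beyond the scatter, so a second group now reads lower than 1,2-bis(methoxycarbonyl)ethyl, although the true size of that step stays unknown. Compound 1 sits at a limit of the assay and not at a number, so the step gives only a minimum: the limit of > 50000 nM in this assay, at which 1 of the 3 values shown sits.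

The groups shown are all open chains built from carbon and oxygen, so it remains open how an amine, a benzyl group or a longer carbon chain on this nitrogen would read. On these data alone, it also remains open whether any exchange at this place can bring the number clearly below the level shared by compound 2 and compound 3.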